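This account rests on a few compounds, and the source may have more. Where it says the series, first, only, none or still open, it means among the compounds named here.

Measured so far in an assay on isolated protein for inhibition of Trypsin (Homo sapiens); on this read-out higher numbers stand for weaker inhibition and lower numbers for stronger inhibition:

compound 1, `CC(C(=O)c1cc(C(F)(F)F)nn1-c1ccc2onc(N)c2c1)c1ccc(-c2ccccc2S(N)(=O)=O)cc1`, gives > 20000 nM, a limit of the assay and not a number.
compound 2, `CS(=O)(=O)c1ccccc1-c1ccc(CC(=O)c2cc(C(F)(F)F)nn2-c2ccc3onc(N)c3c2)cc1`, gives > 20000 nM, again a limit and not a number.

Compound 2 therefore stands at the edge of what this assay can report, and no ranking against compound 1 is possible from the numbers shown. The evidence on any step is thin: the limit of > 20000 nM in this assay, at which 2 of the 2 values shown sit. Within the data shown here, no pair of measured compounds differs in a single place, so no measured step exists to lean on.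

Compound 3, `Nc1noc2ccc(-n3nc(C(F)(F)F)cc3C(=O)Cc3ccc(-c4ccccc4S(N)(=O)=O)cc3)cc12`, differs from compound 2 in one spot: amino in place of methyl on a sulfonyl sulfur. Compound 1 already carries the 2-sulfamoylphenyl group, and compound 1 gives only a limit in this assay. With both measured values sitting at the limit, the step from compound 2 to compound 3 is expected to be none beyond the scatter, a step that the limit leaves unreadable from compound 2 to compound 3, and compound 3 is most likely to return a limit as well. Compound 3 is estimated at 30000 nM, with a range from 12000 nM to 100000 nM.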

Compound 3, inhibition constant: > 20000 nM
Compound 3: no number, only a limit (the forecaster's own chance of this, stated with the estimate: 85%); the middle value lies beyond the limit too.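

Compound 3 gives only a limit in this assay, as compound 1 and compound 2 do, so its steps from compound 1 and from compound 2 cannot be read: the limit of > 20000 nM in this assay, at which 3 of the 3 values shown sit.

The compounds shown leave open how strong any of them really is, and whether amino in place of methyl on a sulfonyl sulfur changes anything.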